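Trimethoxyphenyl amides and ureas: cytotoxicity working notes

This account rests on a few compounds, and the source may have more. Where it says the series, first, only, none or still open, it means among the compounds named here.

Compound 1 `COc1cc(N(C)C(=O)c2ccc(F)cc2)cc(OC)c1OC`: in a functional assay on Daoy cells (Homo sapiens) for cytotoxicity, read by MTT assay, with a stated time of 72 h (on this read-out higher numbers stand for weaker inhibition and lower numbers for stronger inhibition), compound 1 gives only a limit, >= 125000 nM.
Compound 2 `COc1ccc(NC(=O)Nc2cc(OC)c(OC)c(OC)c2)cc1`: in this assay compound 2 gives 14900 nM.
Compound 3 `COc1ccc(C(=O)N(C)c2cc(OC)c(OC)c(OC)c2)cc1`: in this assay compound 3 gives only a limit, >= 125000 nM.

Compound 1 and compound 3 share one core and differ by fluoro in place of methoxy on an aromatic carbon. Both values sit at the limit of >= 125000 nM in this assay, at which 2 of the 3 values shown sit, so the step that the two limits leave unreadable from compound 3 to compound 1 stays unreadable. The difference between the core of compound 2 and the core of compound 3 is not broken down here. Compound 4 `COc1cc(NC(=O)Nc2ccc(F)cc2)cc(OC)c1OC`, not yet measured, relates to compound 2 by the same change, (fluoro in place of methoxy on an aromatic carbon). With the measured instance of this change unreadable, the expectation rests on compound 2 and its value 14900 nM alone, and a step of a 1.3-fold higher number from compound 2 to compound 4 (0.13 log units; within the scatter) is expected, within the usual scatter. Compound 4 is therefore estimated at 20000 nM in this assay, likely between 5000 nM and 90000 nM.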

Compound 4, half-maximal inhibitory concentration: 104000 nM
Compound 4: the middle estimate sits 5.2-fold (0.72 log units) below what was measured, and the stated range ends below it.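

In this assay, fluoro in place of methoxy on the core of compound 2 gives a 7.0-fold higher number from compound 2 to compound 4 (0.84 log units; beyond the scatter), which means weaker inhibition. Compound 1 and compound 3 both give only a limit, so the same change on their shared core cannot be read: the limit of >= 125000 nM in this assay, at which 2 of the 4 values shown sit.

The series therefore holds one readable instance of this change, which shows its size on a single core but not whether that size carries over to another core. The compounds shown leave open how other groups at this place, such as an amine or a carboxylic acid, would read in this assay. They also leave open whether any second core would repeat the step.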